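The source may report more compounds than this note shows. Statements on the series, on what has been measured and on what is new or still open speak of the compounds shown alone.

Compound 3 `CCC(C)OC(=O)C1=C(C)NC(=O)NC1c1cccs1` gives 7% in an assay on membranes from HEK293 cells for displacement of a labelled ligand from adenosine receptor A2b (Homo sapiens), read by scintillation counting, with a stated time of 30 min, tested at 1 uM (on this read-out lower numbers stand for less inhibition and higher numbers for more inhibition at the one concentration tested (going by the name of the read-out)), the second highest of the three numbers. Compound 1 `COC(=O)C1=C(C)NC(=O)NC1c1cccs1` gives 19% and compound 2 `CCC(CC)OC(=O)C1=C(C)NC(=O)NC1c1cccs1` gives 6%. Compound 4 `CC1=C(C(=O)OC2CCCC2)C(c2cccs2)NC(=O)N1` differs from compound 3 by cyclopentyl in place of sec-butyl on an oxygen next to a carbonyl group. For the measured compounds named here, two measured steps bear on this change: a number 12 percentage points lower from compound 1 to compound 3 (beyond the scatter) and a number 13 percentage points lower from compound 1 to compound 2 (beyond the scatter), both modest lowerings when a larger group replaces methyl on that oxygen. By contrast, a number 1 percentage points higher from compound 2 to compound 3 (within the scatter), a move between two such larger groups, lies within the scatter. Cyclopentyl is a further group of that kind, so the expected step is a number 1 percentage points higher from compound 3 to compound 4 (within the scatter), none beyond the scatter. Compound 4 is therefore estimated at 8%, with a range from 0% to 20%.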

Compound 4, a percentage reported as inhibition, at one concentration (the size of the read-out at that concentration, not a potency): 1%
The estimate for compound 4 lay 7 percentage points above the measured number; the range from low to high includes it.
By their numbers in this assay, from the lowest: compounds 4, 2 and 3 (each within the scatter of the next); then compound 1.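

Cyclopentyl brings a ring to the oxygen next to a carbonyl group, yet in this assay it does not stand apart from the open chains: a number 6 percentage points lower from compound 3 to compound 4 (within the scatter) and a number 5 percentage points lower from compound 2 to compound 4 (within the scatter). Set against methyl, it fits the same picture, with a number 18 percentage points lower from compound 1 to compound 4 (beyond the scatter) as the step. No evidence is available to explain these numbers. Open, going by these compounds, is whether phenyl, benzyl or a chain carrying an amine on that oxygen would give numbers like these. Also open, on these data alone, is where the carboxylic acid would fall relative to compound 1.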